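This account rests on a few compounds, and the source may have more. Where it says the series, first, only, none or still open, it means among the compounds named here.

Compound 1 `CN1CCC[C@@H]1Cn1nc(Cc2ccc(O)cc2)c2ccccc2c1=O` gives 398 nM in an assay for binding affinity to Alpha-1B adrenergic receptor (Homo sapiens) (on this read-out higher numbers stand for weaker inhibition and lower numbers for stronger inhibition), the highest of the three numbers: compound 2 `CN(C)CCn1nc(Cc2ccc(Cl)cc2)c2ccccc2c1=O` gives 200 nM, which lies within the scatter of compound 1, while compound 3 `CN1CCC(Cn2nc(Cc3ccc(Cl)cc3)c3ccccc3c2=O)C1` gives 79.4 nM, beyond it. Compound 4 `CN1CCC[C@@H]1Cn1nc(Cc2ccc(F)cc2)c2ccccc2c1=O` differs from compound 1 in one place: fluoro in place of hydroxy on an aromatic carbon. Within the data shown here, the only measured single-place step, a 2.5-fold lower number from compound 2 to compound 3 (0.40 log units; beyond the scatter), concerns the amine side chain and not the aromatic substituent, so it does not bear on this change. Compounds 2 and 3 carry chloro where compound 1 carries hydroxy, but their amine chains also differ, so their values give no clean comparison. Compound 4 is therefore expected to move only modestly, a 1.6-fold lower number from compound 1 to compound 4 (0.20 log units; within the scatter), and is estimated at 250 nM, between 80 nM and 800 nM.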

Compound 4, inhibition constant: 79.4 nM
Beside the measured number, compound 4's estimate is 3.1-fold (0.50 log units) above it; the whole stated range lies above it.
By their numbers in this assay, from the lowest: compounds 3 and 4 (each within the scatter of the next); then compounds 2 and 1 (each within the scatter of the next).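

With the amine chain held fixed, fluoro in place of hydroxy on the aromatic carbon gives a 5.0-fold lower number from compound 1 to compound 4 (0.70 log units; beyond the scatter) in this assay. Among these compounds, this is the first clean reading at this position, and it shows that the group there alone can move the number beyond the scatter, which compounds 2 and 3 could not show, since their amine chains differ as well. Nothing available accounts for the step.

The compounds shown leave open how chloro, methoxy or an amine would read at this position on the chain of compound 1. They also leave open whether the same change would carry over to the amine chain of compound 3.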